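Expected Reductase Inhibition of a Fluoro-Dimethylphenyl Analogue

The source may report more compounds than this note shows. Statements on the series, on what has been measured and on what is new or still open speak of the compounds shown alone.

Compound 3 `Cc1ccc(-c2c(-c3ccc(F)cc3)nc(C(F)(F)F)n2CC[C@@H](O)C[C@@H](O)CC(=O)O)cc1` gives 750 nM in an assay on microsomes from liver for inhibition of 3-hydroxy-3-methylglutaryl-coenzyme A reductase (Rattus norvegicus) (on this read-out higher numbers stand for weaker inhibition and lower numbers for stronger inhibition), the highest number among the three measured compounds; compound 1 `O=C(O)C[C@H](O)C[C@H](O)CCn1c(C(F)(F)F)nc(-c2ccc(F)cc2)c1-c1ccccc1` gives 201 nM and compound 2 `Cc1cccc(-c2c(-c3ccc(F)cc3)nc(C(F)(F)F)n2CC[C@@H](O)C[C@@H](O)CC(=O)O)c1` gives 74 nM. Compound 4 `Cc1cc(-c2c(-c3ccc(F)cc3)nc(C(F)(F)F)n2CC[C@@H](O)C[C@@H](O)CC(=O)O)cc(C)c1F` differs from compound 3 by 4-fluoro-3,5-dimethylphenyl in place of 4-methylphenyl on an aromatic carbon. Within the data shown here, two measured steps bear on this change: a 2.7-fold lower number from compound 1 to compound 2 (0.43 log units; beyond the scatter) and a 3.7-fold higher number from compound 1 to compound 3 (0.57 log units; beyond the scatter), which together amount to a 10-fold higher number from compound 2 to compound 3 (1.01 log units; beyond the scatter). Compound 4 shares methyl on its phenyl with compound 2, which gave 74 nM, while the 4-methylphenyl of compound 3 gives way to a ring bearing fluorine, so a step downward is expected, roughly a 6.8-fold lower number from compound 3 to compound 4 (0.83 log units; beyond the scatter). Compound 4 is therefore estimated at 110 nM in this assay, within a range of 25 nM to 450 nM.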

Compound 4, half-maximal inhibitory concentration: 31 nM
Compound 4: the middle estimate sits 3.5-fold (0.55 log units) above what was measured, within the range that was stated.
By their numbers in this assay, from the lowest: compound 4; then compound 2; then compound 1; then compound 3.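

In this assay the 4-fluoro-3,5-dimethylphenyl group gives the lowest number yet at this position, with a 24-fold lower number from compound 3 to compound 4 (1.38 log units; beyond the scatter) and a 2.4-fold lower number from compound 2 to compound 4 (0.38 log units; beyond the scatter) and also a 6.5-fold lower number from compound 1 to compound 4 (0.81 log units; beyond the scatter) as its steps. A ring with 9 heavy atoms is thus tolerated here, and the weak result for 4-methylphenyl does not extend to every larger substituted phenyl. Nothing available explains this gain. The compounds shown leave open how the fluorine and the two methyl groups share the step, and how a methoxy group or an amine on this ring would read.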